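Phenyl in place of methyl on the core of compound 1

The source may report more compounds than this note shows. Statements on the series, on what has been measured and on what is new or still open speak of the compounds shown alone.

compound 1 `Cc1ccc2c(c1)C(C)(C)[C@H]1COc3ccc4c(=O)c(C)c(C)oc4c3[C@H]1N2`: 94300 nM
compound 2 `Cc1oc2c3c(ccc2c(=O)c1C)OC[C@H]1[C@@H]3Nc2ccccc2C1(C)C`: a limit, > 100000 nM
compound 3 `Cc1ccc2c(c1)C(C)(C)[C@H]1COc3ccc4c(=O)c(C)coc4c3[C@H]1N2`: 10200 nM

In a functional assay on MCF7 cells (Homo sapiens) for antiproliferative activity, read by MTT assay (a higher number here means a weaker inhibitor, a lower number a stronger inhibitor), compound 1 gives 94300 nM, the highest of the two numbers shown; the nearest is compound 3, reached by a 9.2-fold lower number from compound 1 to compound 3 (0.97 log units; beyond the scatter). Compound 2 gives no number but (the limit of > 100000 nM in this assay, at which 1 of the 3 values shown sits). Compound 4 `Cc1ccc2c(c1)C(C)(C)[C@H]1COc3ccc4c(=O)c(-c5ccccc5)c(C)oc4c3[C@H]1N2` differs from compound 1 by phenyl in place of methyl on an aromatic carbon. Both measured steps remove a methyl, none adds a phenyl: a 9.2-fold lower number from compound 1 to compound 3 (0.97 log units; beyond the scatter) concerns the methyl that compound 4 replaces, while an at least 1.0-fold higher number from compound 1 to compound 2 (0.02 log units; that floor lies within the scatter) concerns another methyl. Taking the methyl away helped, but a phenyl is a larger change whose effect is unknown here, so only a modest expected gain is ventured, a 1.9-fold lower number from compound 1 to compound 4 (0.28 log units; within the scatter). Compound 4 is thus estimated at 50000 nM, between 10000 nM and 200000 nM.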

Compound 4, half-maximal inhibitory concentration: 10000 nM
Beside the measured number, compound 4's estimate is 5.0-fold (0.70 log units) above it; measured number inside the range.
By their numbers in this assay, from the lowest: compounds 4 and 3 (each within the scatter of the next); then compound 1. At a limit, above all of these: compound 2.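

In this assay, phenyl in place of methyl two atoms from the ring oxygen gives a 9.4-fold lower number from compound 1 to compound 4 (0.97 log units; beyond the scatter), the first change shown at this carbon. Compound 3 instead lacks the methyl group ortho to this carbon, which compound 4 keeps, so changes at two different places on this ring each give a lower number than compound 1. Nothing measured here accounts for the gain.

On these data alone, whether an amine or a longer chain at this carbon would match phenyl stays open. So does whether the two changes would add up in one compound.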